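The source may hold more compounds than are shown below. What is called first, only, known or untested is meant among the compounds shown, and "the series" means these compounds.

Working notes on the series. Three compounds have numbers in a functional assay (aorta) with Oryctolagus cuniculus as the target; on this read-out lower numbers stand for stronger inhibition and higher numbers for weaker inhibition. Compound 1 `N#Cc1ccccc1Cn1nc(-c2ccc(CO)o2)c2ccccc21` gives 8700 nM. Among the compounds with values here, compound 2 `OCc1ccc(-c2nn(Cc3ccccn3)c3ccccc23)o1` gives 16000 nM; the one step between measured compounds, a 1.8-fold higher number from compound 1 to compound 2 (0.26 log units; within the scatter), is within the scatter, so no order between compound 1 and compound 2 can be read. Compound 3 `CC(C)c1cnc(-c2nn(Cc3ccccc3F)c3ncccc23)nc1N` gives 207000 nM, the highest of the three numbers; the nearest is compound 2 and the furthest is compound 1, both gaps beyond the scatter.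

The next compound is compound 4 `CS(=O)(=O)c1cnc(-c2nn(Cc3ccccc3F)c3ncccc23)nc1N`. It differs from compound 3 in one place: methylsulfonyl in place of isopropyl on an aromatic carbon, on an aromatic carbon of a six-membered aromatic ring with 2 nitrogen. Within the data shown here, no measured step in this assay concerns this change or any change at that place; the only measured step, from compound 1 to compound 2, is at the saturated chain carbon bound to an aromatic nitrogen and tells nothing here. Among the measured compounds shown here, with no step to lean on, the step of a 1.4-fold lower number from compound 3 to compound 4 (0.14 log units; within the scatter) is expected to stay near the scatter, direction undetermined, and the estimate is kept wide. Compound 4 is therefore estimated at 150000 nM, with a range from 30000 nM to 700000 nM.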

Compound 4, half-maximal inhibitory concentration: 261000 nM
Estimate against measurement, compound 4: 1.7-fold (0.24 log units) below; low and high end bracket the measured number.
By their numbers in this assay, from the lowest: compounds 1 and 2 (each within the scatter of the next); then compounds 3 and 4 (each within the scatter of the next).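

In this assay, the step of a 1.3-fold higher number from compound 3 to compound 4 (0.10 log units; within the scatter) lies within the scatter, so methylsulfonyl in place of isopropyl gives no readable order between the two compounds. Within the data shown here, this is the first measured step at this place, on an aromatic carbon of a six-membered aromatic ring with 2 nitrogen, ortho to an amino group, and it shows that this exchange is not resolved by this read-out, even though 3 carbon atoms with 0 hydrogen-bond acceptors give way to a group of 4 heavy atoms with 2 hydrogen-bond acceptors. No accompanying measurement bears on the reason for this result.

A single pair at this place leaves open whether any other group there, such as a carboxylic acid, a primary amine or a longer alkyl chain, would give a step beyond the scatter. From the compounds shown here alone, it also remains open whether the exchange of isopropyl for methylsulfonyl would stay within the scatter with another group on the saturated chain carbon bound to an aromatic nitrogen, or with the amino group replaced by a hydroxyl group.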